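A few compounds are considered here, and "the series" means these few. Any claim that something is new, unique, unknown or untested is made for them only; others in the source may bear on it.

Measured so far in a functional assay for agonist activity at G protein-coupled receptor 88 (Homo sapiens), read by HTRF and cAMP accumulation; on this read-out lower numbers stand for an effect already at smaller amounts and higher numbers for an effect only at larger amounts of compound:
compound 1 `CC(C)C[C@H](N)CN(C(=O)[C@@H]1C[C@H]1c1ccccc1)c1ccc(-c2ccsc2)cc1` gives 1200 nM
compound 2 `CC(C)C[C@H](N)CN(C(=O)[C@@H]1C[C@H]1c1ccccc1)c1ccc(-c2ccoc2)cc1` gives 2000 nM
compound 3 `CC(C)C[C@H](N)CN(C(=O)[C@@H]1C[C@H]1c1ccccc1)c1ccc(C2=CCCC2)cc1` gives 1200 nM

Compound 3 stands level with compound 1 at the digits printed, the two together giving the lowest numbers of the three; compound 2 sits furthest, with a 1.7-fold lower number from compound 2 to compound 3 (0.22 log units; within the scatter). Compound 4 `CC(C)C[C@H](N)CN(C(=O)[C@@H]1C[C@H]1c1ccccc1)c1ccc(C2=CCCCC2)cc1` carries the next change: cyclohex-1-en-1-yl in place of cyclopent-1-en-1-yl on an aromatic carbon. For the measured compounds named here, the steps that bear on it are the earlier swaps at the same aromatic carbon: a 1.7-fold higher number from compound 1 to compound 2 (0.22 log units; within the scatter), no change at the digits printed from compound 1 to compound 3 (within the scatter) and a 1.7-fold lower number from compound 2 to compound 3 (0.22 log units; within the scatter), none of them beyond the scatter. On that basis the expected change in this assay is no change at the digits printed from compound 3 to compound 4 (within the scatter), nothing beyond the scatter. Compound 4 is accordingly estimated at 1200 nM, with a range from 450 nM to 3200 nM.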

Compound 4, half-maximal effective concentration: 1200 nM
Compound 4: middle estimate and measured number agree at the digits printed; the measured number falls inside the stated range.
By their numbers in this assay, from the lowest: compounds 1, 3, 4 and 2 (each within the scatter of the next).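

Taking cyclohex-1-en-1-yl in place of cyclopent-1-en-1-yl gives no change at the digits printed from compound 3 to compound 4 (within the scatter) in this assay, so a six-membered non-aromatic ring of carbon only reads the same here as the five-membered one. Set against the two aromatic rings, the new group gives no change at the digits printed from compound 1 to compound 4 (within the scatter) and a 1.7-fold lower number from compound 2 to compound 4 (0.22 log units; within the scatter), which extends the flat picture at this aromatic carbon to a fourth group. No measured evidence accounts for this flatness. As far as these compounds go, whether an amine, a carboxylic acid or a saturated cyclohexyl ring here would give a step beyond the scatter remains open.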